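Moving One Methoxy Group: From Compound 3 to Compound 4

This account rests on a few compounds, and the source may have more. Where it says the series, first, only, none or still open, it means among the compounds named here.

Compound 1 `O=[N+]([O-])c1cccc(Nc2nc(SCc3ccc(C(F)(F)F)cc3)nc3ccccc23)c1`: in a functional assay on MGC-803 cells (Homo sapiens) for cytotoxicity, read by MTT assay, with a stated time of 72 h (on this read-out higher numbers stand for weaker inhibition and lower numbers for stronger inhibition), compound 1 gives > 50000 nM, a limit of the assay.
Compound 2 `Cc1ccc(Nc2nc(SCc3ccc(C(F)(F)F)cc3)nc3ccccc23)cc1`: in this assay compound 2 gives 36100 nM.
Compound 3 `COc1ccc(Nc2nc(SCc3ccc(C(F)(F)F)cc3)nc3ccccc23)c(OC)c1`: in this assay compound 3 gives > 50000 nM, a limit of the assay.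

Compound 3 therefore stands only at a limit, one of the two values sitting at the limit of > 50000 nM in this assay, at which 2 of the 3 values shown sit. Compound 4 `COc1ccc(Nc2nc(SCc3ccc(C(F)(F)F)cc3)nc3ccccc23)cc1OC` differs from it by 3,4-dimethoxyphenyl in place of 2,4-dimethoxyphenyl on a nitrogen on an aromatic ring. For the measured compounds named here, no measured step compares these two groups directly. The steps that reach compound 3 are a step that the two limits leave unreadable from compound 1 to compound 3 and an at least 1.3-fold higher number from compound 2 to compound 3 (0.14 log units; that floor lies within the scatter), neither of which reads as a step beyond the scatter. Nothing measured points to a change in either direction, so no step beyond the scatter is expected in this assay. Compound 4 is thus expected to show a number no higher from compound 3 to compound 4 (the limit leaves the size open). The estimate for compound 4 is 50000 nM, expected to fall between 20000 nM and 120000 nM.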

Compound 4, half-maximal inhibitory concentration: 16300 nM
Compound 4: the middle estimate sits 3.1-fold (0.49 log units) above what was measured; measured number below the stated range.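

In this assay 3,4-dimethoxyphenyl in place of 2,4-dimethoxyphenyl gives an at least 3.0-fold lower number from compound 3 to compound 4 (0.48 log units; beyond the scatter) from the same atoms joined differently, so the placement of the methoxy groups alone moves the read-out beyond the scatter at this position. With a 2.2-fold lower number from compound 2 to compound 4 (0.35 log units; beyond the scatter) and an at least 3.0-fold lower number from compound 1 to compound 4 (0.48 log units; beyond the scatter) the same group also stands apart from 4-methylphenyl and 3-nitrophenyl. Two of the steps rest on a limit and so give only a floor: the limit of > 50000 nM in this assay, at which 2 of the 4 values shown sit.

The compounds shown leave open whether a single methoxy group on this ring would carry the same step. They also leave open how an ethoxy group, a hydroxyl group or an amine would read here.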